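The source may report more compounds than this note shows. Statements on the series, on what has been measured and on what is new or still open speak of the compounds shown alone.

Measured compounds and their results:

compound 1 `CN(C)c1ccc(/C=C(/SCc2ccc(Cl)cc2)C(=O)c2ccc(C(=O)O)cc2)cc1` gives 1000 nM
compound 2 `CN(C)c1ccc(/C=C(/SCc2ccc(Br)cc2)C(=O)c2ccc(C(=O)O)cc2)cc1` gives 50000 nM
compound 3 `Cc1ccc(S/C(=C/c2c[nH]c3ccc(Cl)cc23)C(=O)c2ccc(Br)cc2)cc1` gives 1000 nM

All three were tested in a functional assay on DU-145 cells (Homo sapiens) for inhibition, read by trypan blue exclusion, with a stated time of 96 h; on this read-out lower numbers stand for stronger inhibition of growth and higher numbers for weaker inhibition of growth. Compounds 1 and 2 share one core and differ only in one place: chloro in place of bromo on an aromatic carbon. That single exchange made a large step, a 50-fold lower number from compound 2 to compound 1 (1.70 log units; beyond the scatter). Compound 3 is built on a different core; how its core differs from that of compound 2 is not broken down here. In this assay compound 3 gives 1000 nM, level with compound 1 at the digits shown, so no order can be read between those two.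

Compound 4 `Cc1ccc(S/C(=C/c2c[nH]c3ccc(Cl)cc23)C(=O)c2ccc(Cl)cc2)cc1` is not yet measured. It differs from compound 3 by chloro in place of bromo on an aromatic carbon. This is the same change as the one between compounds 2 and 1, and the place around it is described in the same words in both pairs, so among these compounds the exchange appears in two pairs. Only one of the two is measured, and it sits on a different core and a different arm of the molecule, so the large earlier step is a weak guide for the size of the new one. Within the data shown here, a smaller step in the same direction is expected, a 2.5-fold lower number from compound 3 to compound 4 (0.40 log units; beyond the scatter), because the one measured example gave a 50-fold lower number from compound 2 to compound 1 (1.70 log units; beyond the scatter) while a single example cannot show how far this carries over. Compound 4 is therefore estimated at 400 nM, within 100 nM to 2000 nM.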

Compound 4, concentration for 50% growth inhibition: 1000 nM
Compound 4: the middle estimate sits 2.5-fold (0.40 log units) below what was measured; measured number inside the range.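

In this assay, the exchange of bromo for chloro, here 4-bromophenyl to 4-chlorophenyl, gave no change at the digits printed from compound 3 to compound 4 (within the scatter). Set beside the earlier pair, this shows that the same small exchange, one halogen atom for another, did not give a step of the same size on both cores, so the result from one core could not be carried over to the other in this series: the same change on two cores in this assay, a 50-fold lower number (1.70 log units; beyond the scatter) from compound 2 to compound 1 and no change at the digits printed (within the scatter) from compound 3 to compound 4, 50-fold (1.70 log units) apart, beyond the scatter of two such steps With only two pairs, this does not show which of the many differences between the two cores goes with the gap, nor which of the two steps would be the more typical one on a further core.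

The compounds shown leave open what other groups would do at this place on the core of compound 3, for instance fluoro, a nitrile or a methoxy group, as only bromo and chloro appear there. They also leave open whether a third core, or a carboxylic acid brought onto the core of compound 3, would follow the large step or the absent one.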